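A few compounds are considered here, and "the series" means these few. Any claim that something is new, unique, unknown or untested is made for them only; others in the source may bear on it.

Going by the values given here, in a functional assay on U-87MG ATCC cells (Homo sapiens) for antiproliferative activity (on this read-out higher numbers stand for weaker inhibition and lower numbers for stronger inhibition), compound 1 `Cc1c2c(n3c1CCN(C(=O)CN)C[C@@H](C)[C@H](C)Nc1cc-3ccc1C(N)=O)CC(C)(C)CC2=O` gives 378 nM, while compound 2 `Cc1c2c(n3c1CCN(C(=O)[C@@H](N)C(C)C)C[C@@H](C)[C@H](C)Nc1cc-3ccc1C(N)=O)CC(C)(C)CC2=O` gives 48 nM, the lower of the two numbers so far. Compound 3 `Cc1c2c(n3c1CCN(C(=O)C(C)(C)N)C[C@@H](C)[C@H](C)Nc1cc-3ccc1C(N)=O)CC(C)(C)CC2=O` departs from compound 2 as follows: 1-amino-1-methylethyl in place of 1-amino-2-methylpropyl on a carbonyl carbon. Among the compounds with values here, only one measured step bears on this change at the same carbonyl carbon: a 7.9-fold lower number from compound 1 to compound 2 (0.90 log units; beyond the scatter). Within the data shown here, that single step, beyond the scatter, shows that the group here can shift the number, but no measured compound carries 1-amino-1-methylethyl. A smaller move towards a higher number is expected, a 2.3-fold higher number from compound 2 to compound 3 (0.36 log units; beyond the scatter). The estimated value for compound 3 is 110 nM, within an expected range of 40 nM to 300 nM.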

Compound 3, half-maximal inhibitory concentration in the U-87MG ATCC assay: 39 nM
Compound 3: the middle estimate sits 2.8-fold (0.45 log units) above what was measured, and the stated range ends above it.
By their numbers in the U-87MG ATCC assay, from the lowest: compounds 3 and 2 (each within the scatter of the next); then compound 1.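

In the U-87MG ATCC assay, 1-amino-1-methylethyl in place of 1-amino-2-methylpropyl on this carbonyl carbon gives a 1.2-fold lower number from compound 2 to compound 3 (0.09 log units; within the scatter), so in this pair the defined stereocentre that leaves with 1-amino-2-methylpropyl is not needed to hold the number. Against aminomethyl, the same group gives a 9.7-fold lower number from compound 1 to compound 3 (0.99 log units; beyond the scatter), so a step of this kind from compound 1 does not depend on the isopropyl of compound 2.

In a physicochemical assay for solubility, at pH 7.4 (a lower number here means a less soluble compound, a higher number a more soluble compound), compound 2 gives > 100 ug/mL, which is a limit of the assay and not a number. In the physicochemical assay compound 3 gives > 100 ug/mL, which is also a limit of the assay and not a number. In the physicochemical assay the step from compound 2 to compound 3 cannot be read, since both values are limits: the limit of > 100 ug/mL in the physicochemical assay, at which 2 of the 2 values shown sit. Open, as far as these compounds go, is how a longer chain on this carbon, or a cyclopropyl ring carrying the amine, would read in the U-87MG ATCC assay.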